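The source may report more compounds than this note shows. Statements on the series, on what has been measured and on what is new or still open speak of the compounds shown alone.

Measured so far:
compound 1 `COc1ccc(-c2cc(/C=C/C(=O)c3ccc(N)cc3)[nH]n2)cc1` — 39800 nM
compound 2 `COc1ccc(-c2cc(/C=C/C(=O)c3ccc(N)cc3)[nH]n2)cc1OC` — > 100000 nM
compound 3 `COc1cc(C(=O)/C=C/c2cc(-c3cc(OC)c(OC)c(OC)c3)n[nH]2)cc(OC)c1OC` — 7360 nM

In a functional assay on PC-3 cells (Homo sapiens) for inhibition, read by sulforhodamine B assay, with a stated time of 48 h (a lower number here means that less compound is tolerated, a higher number that more compound is tolerated), compound 1 gives 39800 nM. For compound 2 the value in this assay is only a limit of the assay, > 100000 nM. Compound 3 gives 7360 nM in this assay, the lowest of the two numbers.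

Compound 1 differs from compound 2 by hydrogen in place of methoxy on an aromatic carbon. This gave an at least 2.5-fold lower number from compound 2 to compound 1 (0.40 log units; beyond the scatter); because compound 2 sits at the limit of > 100000 nM in this assay, at which 1 of the 3 values shown sits, only the lower bound of that step is known.

Compound 4 `COc1ccc(-c2cc(/C=C/C(=O)c3cc(OC)c(OC)c(OC)c3)[nH]n2)cc1OC` is not yet measured. It differs from compound 3 by hydrogen in place of methoxy on an aromatic carbon. For the measured compounds named here, this is the same kind of change as the one from compound 2 to compound 1, but not the same: here the place is also meta to a methoxy group. The difference between the two cores is not broken down here.

Based on the step from compound 2 to compound 1, compound 4 is expected to show a 1.5-fold lower number from compound 3 to compound 4 (0.17 log units; within the scatter) in this assay. Compound 4 is therefore estimated at 5000 nM, between 1500 nM and 20000 nM.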

Compound 4, concentration lethal to 50% of the cells: 48200 nM
Beside the measured number, compound 4's estimate is 9.6-fold (0.98 log units) below it; measured number outside the range, above it.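

In this assay, putting hydrogen in place of one methoxy group on an aromatic carbon gives a 6.5-fold higher number from compound 3 to compound 4 (0.82 log units; beyond the scatter). Set beside the earlier case, the same swap moves the number in opposite directions on the two cores: the same change on two cores in this assay, an at least 2.5-fold lower number (0.40 log units; beyond the scatter) from compound 2 to compound 1 and a 6.5-fold higher number (0.82 log units; beyond the scatter) from compound 3 to compound 4, at least 16-fold (1.21 log units) apart, beyond the scatter of two such steps This shows that the result of this swap on one core cannot simply be carried over to the other in these two pairs, but it does not show why they part, and two pairs are too few to give a rule for the series; the earlier step is also only a bound, since the value of compound 2 is a limit of the assay: the limit of > 100000 nM in this assay, at which 1 of the 4 values shown sits.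

The compounds shown leave open how the same swap would behave on any further core. They also leave open whether a hydroxyl group or a fluorine atom in that place would follow the pair of compound 3 and compound 4 or the pair of compound 2 and compound 1.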